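The source may report more compounds than this note shows. Statements on the series, on what has been measured and on what is new or still open speak of the compounds shown alone.

Compound 1 `CC(C)n1cnc2c(NC(=N)N)nc(N)nc21`: 97200 nM
Compound 2 `CC(C)n1cnc2c(NC(=N)N)nc(NCCCO)nc21`: 8800 nM
Compound 3 `CC(C)n1cnc2c(NC(=N)N)nc(NCCCCCCO)nc21`: 5200 nM

In a functional assay on MCF7 cells (Homo sapiens) for inhibition, read by fluorescence, with a stated time of 72 h (on this read-out lower numbers stand for stronger inhibition and higher numbers for weaker inhibition), compound 3 cannot be told apart from compound 2, given a 1.7-fold lower number from compound 2 to compound 3 (0.23 log units; within the scatter), but it stands clear of compound 1, given a 19-fold lower number from compound 1 to compound 3 (1.27 log units; beyond the scatter). Compound 4 `CC[C@@H](N)COc1nc(NC(=N)N)c2ncn(C(C)C)c2n1` has 2-aminobutoxy in place of (6-hydroxyhexyl)amino on an aromatic carbon. For the measured compounds named here, no measured step makes this exchange. The closest evidence is that placing a chain on the nitrogen gave an 11-fold lower number from compound 1 to compound 2 (1.04 log units; beyond the scatter), whereas the longer chain brought no change beyond the scatter. Compound 4 also carries a chain, so it is expected to stay near compound 3, with no shift beyond the scatter in this assay, though with wide uncertainty. The estimated step is a 1.2-fold higher number from compound 3 to compound 4 (0.06 log units; within the scatter). Compound 4 is expected at about 6000 nM, with an estimated range of 1500 nM to 25000 nM.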

Compound 4, half-maximal inhibitory concentration: > 100000 nM
Compound 4: a limit, no number (the forecaster's own chance of this, stated with the estimate: 8%); middle value at least 16-fold (1.22 log units) away from the limit.
By their numbers in this assay, from the lowest: compounds 3 and 2 (each within the scatter of the next); then compound 1. At a limit, above all of these: compound 4.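

The aromatic carbon between two ring nitrogen atoms does not accept every chain: 2-aminobutoxy in place of (6-hydroxyhexyl)amino gives an at least 19-fold higher number from compound 3 to compound 4 (1.28 log units; beyond the scatter), and in place of (3-hydroxypropyl)amino it gives an at least 11-fold higher number from compound 2 to compound 4 (1.05 log units; beyond the scatter). In place of the plain amino group it gives an at least 1.0-fold higher number from compound 1 to compound 4 (0.01 log units; that floor lies within the scatter), so carrying a chain here does not by itself lower the number. Compound 4 stands at a limit and not at a number: the limit of > 100000 nM in this assay, at which 1 of the 4 values shown sits.

The compounds shown leave open which part of the exchange goes with this step, the oxygen linking the chain or the amine on it. A 6-hydroxyhexyloxy or a (6-aminohexyl)amino group on this carbon would separate the two.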